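Methoxy to ethoxy on the shared core

The source may hold more compounds than are shown below. What is called first, only, known or untested is meant among the compounds shown, and "the series" means these compounds.

Of the compounds shown here, three have been read in an assay for inhibition of Receptor tyrosine-protein kinase erbB-3 variant L858R (Homo sapiens), read by mobility shift assay, with a stated time of 10 min; on this read-out lower numbers stand for stronger inhibition and higher numbers for weaker inhibition. Compound 1 `CCNc1cc(Nc2cccc(Cl)c2)ncn1` gives only a limit there, > 10000 nM, which is a boundary of the assay and not a number; it is the one case of the limit of > 10000 nM in this assay, at which 1 of the 3 values shown sits. Compound 2 `COc1ccc(Nc2cc(NC(=O)c3ccccc3)ncn2)cc1` gives 60 nM in this assay, the lowest of the two real numbers; compound 3 `O=C(Nc1cc(Nc2ccc(Cl)cc2)ncn1)c1ccc(F)cc1` gives 1610 nM, and the gap between the two lies beyond the usual scatter. Compound 2 is therefore the reference point for the next change.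

Compound 4 `CCOc1ccc(Nc2cc(NC(=O)c3ccccc3)ncn2)cc1` has not yet been measured. It differs from compound 2 by methyl in place of hydrogen on a saturated chain carbon bound to an oxygen on an aromatic ring, read one bond further out as methoxy to ethoxy. Within the data shown here, no pair of measured compounds differs in just this way, so no measured step guides the expectation. The added methyl is expected to move this assay by no more than the scatter, in either direction. For compound 4 the estimate is 80 nM, with a range from 25 nM to 250 nM. The estimated step of a 1.3-fold higher number from compound 2 to compound 4 (0.12 log units; within the scatter) is expected to be small and could fall on either side of no change.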

Compound 4, half-maximal inhibitory concentration: 1210 nM
For compound 4 the middle estimate is 15-fold (1.18 log units) below the measured one, outside the stated range (above it).
By their numbers in this assay, from the lowest: compound 2; then compounds 4 and 3 (each within the scatter of the next). At a limit, above all of these: compound 1.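

Among these compounds, the change of methoxy to ethoxy is the first comparison that differs in one place, and in this assay it gives a 20-fold higher number from compound 2 to compound 4 (1.30 log units; beyond the scatter), a large step for a single added methyl. Among the compounds shown here, the position therefore does not tolerate every small extension: a methyl in place of hydrogen on a saturated chain carbon bound to an oxygen on an aromatic ring is enough to move the read-out well beyond the scatter, which the earlier compounds, none of them a one-place pair, could not show. For the compounds shown here, nothing measured so far accounts for the size of this step, and the single step gives no reason for it.

Going by these compounds, with one step at this position, it remains open whether the trend continues or levels off with a longer chain such as propoxy or a branched one such as isopropoxy, and whether a smaller group such as hydroxy or a halogen in place of methoxy holds the read-out. On these data alone, it also remains open whether the same change has a step of similar size on an amide other than the benzamide of compound 2.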